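Replacing 4-chlorophenyl with 1H-indol-5-yl on a shared core

The compounds below may be only part of what the source reports. "The series", "measured", "known", "first", "only" and "open" are said of these compounds alone.

In a functional assay on HepG2 cells (Homo sapiens) for inhibition, read by MTT assay, with a stated time of 48 h (on this read-out lower numbers stand for stronger inhibition and higher numbers for weaker inhibition), compound 1 `COc1cc(-c2nccn3cc(-c4ccc(F)cc4)nc23)cc(OC)c1OC` gives 217 nM and compound 2 `COc1cc(-c2nccn3cc(-c4ccc(Cl)cc4)nc23)cc(OC)c1OC` gives 475 nM, so compound 2 holds the higher of the two numbers and the weaker inhibition. Compound 3 `COc1cc(-c2nccn3cc(-c4ccc5[nH]ccc5c4)nc23)cc(OC)c1OC` keeps the shared core but differs from compound 2 as follows: 1H-indol-5-yl in place of 4-chlorophenyl on an aromatic carbon. In short, 1H-indol-5-yl stands in place of 4-chlorophenyl on an aromatic carbon. Within the data shown here, only one measured step bears on this change, a 2.2-fold higher number from compound 1 to compound 2 (0.34 log units; beyond the scatter), and it swaps a single halogen rather than the whole group, so it is a weak guide. With compound 2 at the top of this small range at 475 nM, a moderate move towards a lower number is expected in this assay, though with wide uncertainty. The expected change is a 3.2-fold lower number from compound 2 to compound 3 (0.50 log units; beyond the scatter). For compound 3 the estimated value is 150 nM, within an expected range of 40 nM to 550 nM.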

Compound 3, half-maximal inhibitory concentration: 146 nM
Estimate against measurement, compound 3: 1.0-fold (0.01 log units) above; the range from low to high includes it.
By their numbers in this assay, from the lowest: compounds 3 and 1 (each within the scatter of the next); then compound 2.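

The earlier compounds shown here showed only one halogen swapped for another, whereas here, in this assay, the whole 4-chlorophenyl group at this aromatic carbon of the shared core gives way to 1H-indol-5-yl, with a 3.3-fold lower number from compound 2 to compound 3 (0.51 log units; beyond the scatter) as the outcome. Against 4-fluorophenyl the same group gives a 1.5-fold lower number from compound 1 to compound 3 (0.17 log units; within the scatter), so this position accommodates a group of two aromatic rings with a hydrogen-bond donor about as well as it does 4-fluorophenyl. Nothing available explains why compound 2 stands apart from the other two.

The compounds shown leave open whether the hydrogen on the ring nitrogen of 1H-indol-5-yl contributes to the result, which a 1-methylindol-5-yl or benzofuran-5-yl group at this carbon could test. They also leave open how a phenyl group bearing an amine or a carboxylic acid would fare here.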